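Pyrazine series: carbon-linked side chain in place of thioether

This account rests on a few compounds, and the source may have more. Where it says the series, first, only, none or still open, it means among the compounds named here.

Of the compounds shown here, three of the shared core have been measured so far. Compound 1 `CCc1nc(-c2ccc(Cl)cc2Cl)c(CC)nc1SC(C)CC` gives 401 nM in an assay on IMR-32 cells for displacement of a labelled ligand from corticotropin-releasing factor receptor 1 (Homo sapiens), read by scintillation counting, with a stated time of 2 h; on this read-out higher numbers stand for weaker inhibition and lower numbers for stronger inhibition. Compound 2 `CCOc1nc(-c2ccc(Cl)cc2Cl)c(CC)nc1NC(CC)CC` gives 151 nM in the same assay, and compound 3 `CCc1nc(-c2cnc(OC)nc2OC)c(CC)nc1NC(CC)CC` gives 17.2 nM. On these numbers compound 1 stands highest of the three; compound 2 is its nearest neighbour, and compound 3 lies furthest from it, both differences beyond the usual scatter. Among the measured compounds shown here, no pair among the measured compounds differs in a single place, so no direct step between measured compounds is available, and compound 3 differs from compound 1 in more than one position at once.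

The next compound, compound 4 `CCc1nc(-c2ccc(Cl)cc2Cl)c(CC)nc1CC(CC)CC`, is derived from compound 1 by one change: 2-ethylbutyl in place of (sec-butyl)sulfanyl on an aromatic carbon

For the measured compounds named here, nothing among the measured compounds isolates the effect of this change, so the step has to be guessed. The expectation is a small step, if any, from compound 1 to compound 4, probably not beyond the scatter, with a slight lean toward a lower number: a 1.3-fold lower number from compound 1 to compound 4 (0.13 log units; within the scatter). The estimate for compound 4 in this assay is therefore 300 nM, within a range of 80 nM to 1200 nM.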

Compound 4, inhibition constant: 68 nM
Compound 4: the middle estimate sits 4.4-fold (0.64 log units) above what was measured, and the stated range ends above it.
By their numbers in this assay, from the lowest: compound 3; then compound 4; then compound 2; then compound 1.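

In this assay, the exchange of (sec-butyl)sulfanyl for 2-ethylbutyl on this aromatic carbon next to the ring nitrogen gives a 5.9-fold lower number from compound 1 to compound 4 (0.77 log units; beyond the scatter), beyond the scatter, so this position responds to the change and the side chain is not interchangeable here. On the core of compound 1, neither the sulfur nor the hydrogen-bond acceptor counted for the (sec-butyl)sulfanyl group is needed to reach this level, since the all-carbon 2-ethylbutyl chain gives the lower number. The exchange alters the linking atom and the chain at once, and no measurement at hand gives a reason for the step.

Still open, from the compounds shown here alone, is how much of the step belongs to the loss of sulfur and how much to the chain itself: a (1-ethylpropyl)sulfanyl group or a 2-methylbutyl chain at the same carbon would begin to separate the two. Also open, going by these compounds, is whether the 2-ethylbutyl chain gives a similar step with the other aromatic substituent carried by compound 3, which stands at 17.2 nM with its amine-linked side chain.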